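The source may hold more compounds than are shown below. What is called first, only, known or untested is meant among the compounds shown, and "the series" means these compounds.

Measured compounds in the series:

- compound 1 `C/C(=N\NC(=O)/C(C#N)=C/c1ccc(O)cc1)c1c(O)c2ccc(O)cc2oc1=O`, which in a functional assay on HeLa cells (Homo sapiens) for cytotoxicity, read by MTT assay, with a stated time of 24 h (on this read-out higher numbers stand for weaker inhibition and lower numbers for stronger inhibition), gives 6020 nM
- compound 2 `C/C(=N\NC(=O)/C(C#N)=C/c1ccc(N(C)C)cc1)c1c(O)c2ccc(O)cc2oc1=O`, which in this assay gives 5140 nM
- compound 3 `C/C(=N\NC(=O)/C(C#N)=C/c1ccc([N+](=O)[O-])cc1)c1c(O)c2ccc(O)cc2oc1=O`, which in this assay gives 8360 nM

Compound 1 has the second highest of the three numbers in this assay; the nearest is compound 2, with a 1.2-fold lower number from compound 1 to compound 2 (0.07 log units; within the scatter), and the furthest is compound 3, with a 1.4-fold higher number from compound 1 to compound 3 (0.14 log units; within the scatter). The remaining measured pair gives a 1.6-fold higher number from compound 2 to compound 3 (0.21 log units; within the scatter). All three steps lie within the scatter, so the aryl substituent has not yet shifted the read-out in any resolvable way.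

Compound 4 `C/C(=N\NC(=O)/C(C#N)=C/c1cccc(Br)c1)c1c(O)c2ccc(O)cc2oc1=O` is the next entry. Relative to compound 1 the change is 3-bromophenyl in place of 4-hydroxyphenyl on a double-bonded chain carbon bound to a double-bonded chain carbon. The three measured steps bear on it only loosely: they exchange one group for another on an aromatic carbon of the same aryl ring, whereas here the whole 4-hydroxyphenyl group gives way to 3-bromophenyl. Since none of those exchanges moved the number beyond the scatter, no step beyond the scatter is expected, in either direction, for a 1.2-fold higher number from compound 1 to compound 4 (0.07 log units; within the scatter). Compound 4 is accordingly estimated at 7000 nM, with a range from 3500 nM to 14000 nM.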

Compound 4, half-maximal inhibitory concentration: 24300 nM
Compound 4: middle estimate off by 3.5-fold (0.54 log units), on the low side; the whole stated range lies below it.
By their numbers in this assay, from the lowest: compounds 2, 1 and 3 (each within the scatter of the next); then compound 4.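

For the compounds shown here, replacing the whole aryl group on a double-bonded chain carbon bound to a double-bonded chain carbon is the first change to move the number in this assay beyond the scatter, with a 4.0-fold higher number from compound 1 to compound 4 (0.61 log units; beyond the scatter) and a 2.9-fold higher number from compound 3 to compound 4 (0.46 log units; beyond the scatter) and also a 4.7-fold higher number from compound 2 to compound 4 (0.67 log units; beyond the scatter) all at this one position. All three steps run toward weaker inhibition, so this position responds to the exchange of 3-bromophenyl for any of the three 4-substituted phenyl groups, although those three groups stay within the scatter of one another. No measurement at hand accounts for the shift.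

Compound 4 differs from the others in both the substituent and its ring position, so the shown compounds cannot assign the step to bromine itself or to where it sits. A 4-bromophenyl or 3-hydroxyphenyl group would separate the two, and an unsubstituted phenyl group would give the baseline for the position.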